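This account rests on a few compounds, and the source may have more. Where it says the series, first, only, none or still open, it means among the compounds named here.

Compound 1 `N#Cc1cc(-c2nc(C(c3ccc(F)cc3)c3ccc(F)cc3)sc2CC(=O)O)ccc1F`: 80%
Compound 2 `NS(=O)(=O)c1ccc(-c2nc(C(c3ccc(F)cc3)c3ccc(F)cc3)sc2CC(=O)O)cc1`: 80%
Compound 3 `NS(=O)(=O)c1cccc(-c2nc(C(c3ccc(F)cc3)c3ccc(F)cc3)sc2CC(=O)O)c1`: 55%

In an in vitro functional assay on HEK285-7 cells for antagonist activity at prostaglandin D2 receptor 2 (Homo sapiens), read by BRET and beta-arrestin recruitment (a lower number here means a smaller maximal response, a higher number a larger maximal response), compound 3 gives 55%, the lowest of the three measured values. The steps of a number 25 percentage points lower from compound 1 to compound 3 (beyond the scatter) and a number 25 percentage points lower from compound 2 to compound 3 (beyond the scatter) both lie beyond the scatter, whereas no change at the digits printed from compound 1 to compound 2 (within the scatter). Compound 4 `O=C(O)Cc1sc(C(c2ccc(F)cc2)c2ccc(F)cc2)nc1-c1cccc(F)c1` differs from compound 3 by one change: fluoro in place of sulfamoyl on an aromatic carbon. Among the compounds with values here, no measured step swaps a sulfamoyl for a fluoro, so the steps leading to compound 3 only show that changing this ring moves the maximal response by modest amounts. A modest rise is therefore expected for compound 4, because a number 25 percentage points lower from compound 1 to compound 3 (beyond the scatter) and a number 25 percentage points lower from compound 2 to compound 3 (beyond the scatter) mark compound 3 as the low outlier. Compound 4 is estimated at 70%, within 55% to 85%, an expected step of a number 15 percentage points higher from compound 3 to compound 4 (beyond the scatter).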

Compound 4, largest response reached (reported as efficacy), in percent of the reference or control that the assay uses: 80%
For compound 4 the middle estimate is 10 percentage points below the measured one; the measured number falls inside the stated range.
By their numbers in this assay, from the lowest: compound 3; then compounds 1, 2 and 4 (each within the scatter of the next).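

In this assay, the change from 3-sulfamoylphenyl to 3-fluorophenyl gives a number 25 percentage points higher from compound 3 to compound 4 (beyond the scatter), so the low value of compound 3 goes with the sulfamoyl group, not with simply having a group at this place, meta to a large group. The fluoro compound also sits level with the others, showing no change at the digits printed from compound 2 to compound 4 (within the scatter) and no change at the digits printed from compound 1 to compound 4 (within the scatter). Nothing available here gives a reason for this difference between sulfamoyl and fluoro.

As far as these compounds go, whether an amine or a carboxylic acid at this place would match compound 4 or compound 3 stays open. So does whether a single methyl group would keep the response of compound 4.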